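The compounds below may be only part of what the source reports. "The series", "measured", "known", "first", "only" and "open" are said of these compounds alone.

Working notes on the series. Of the compounds shown here, three with a shared core have been measured: compound 1 `CCOC(=O)c1cnc(-c2ccc(OC)cc2)nc1NN1C(=O)C=C(C)C1=O`, compound 2 `CCOC(=O)c1cnc(-c2ccc(F)cc2)nc1NN1C(=O)C=C(C)C1=O` and compound 3 `CCOC(=O)c1cnc(-c2ccc(Cl)cc2)nc1NN1C(=O)C=C(C)C1=O`. In a functional assay on Jurkat cells for inhibition of nuclear factor NF-kappa-B complex (Homo sapiens) (a higher number here means a weaker inhibitor, a lower number a stronger inhibitor), compound 1 gives 900 nM, compound 2 gives 700 nM and compound 3 gives 300 nM. Compound 2 thus holds the second highest of the three numbers: the step of a 1.3-fold lower number from compound 1 to compound 2 (0.11 log units; within the scatter) lies within the scatter, whereas a 2.3-fold lower number from compound 2 to compound 3 (0.37 log units; beyond the scatter) and a 3.0-fold lower number from compound 1 to compound 3 (0.48 log units; beyond the scatter) both lie beyond it, though only modestly.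

The next compound, compound 4 `CCOC(=O)c1cnc(C(=O)c2ccco2)nc1NN1C(=O)C=C(C)C1=O`, differs from compound 2 in a single place: (furan-2-yl)carbonyl in place of 4-fluorophenyl on an aromatic carbon. None of the three measured steps bears directly on this change. Each of them exchanges one substituent on the six-membered aromatic ring of carbon only while keeping that ring; here the whole 4-fluorophenyl leaves and a (furan-2-yl)carbonyl enters. The measured steps therefore give only a sense of scale, the whole spread of the three numbers being modest.

With no closer guide, the step of a 2.1-fold higher number from compound 2 to compound 4 (0.33 log units; beyond the scatter) is expected to be a modest weakening, with wide uncertainty in both directions. For compound 4 the estimate in this assay is 1500 nM, within a range from 300 nM to 7000 nM.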

Compound 4, half-maximal inhibitory concentration: 700 nM
Compound 4: the middle estimate sits 2.1-fold (0.33 log units) above what was measured; the range from low to high includes it.
By their numbers in this assay, from the lowest: compound 3; then compounds 2, 4 and 1 (each within the scatter of the next).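

At the aromatic carbon between two ring nitrogen atoms, the six-membered aromatic ring of carbon only proves not to be needed for a number in this range in this assay: a (furan-2-yl)carbonyl, with its five-membered aromatic ring with 1 hetero atom and a double bond outside aromatic rings, matches 4-fluorophenyl (no change at the digits printed from compound 2 to compound 4 (within the scatter)) and 4-methoxyphenyl (a 1.3-fold lower number from compound 1 to compound 4 (0.11 log units; within the scatter)). Among the four compounds, only 4-chlorophenyl stands apart from the new group (a 2.3-fold higher number from compound 3 to compound 4 (0.37 log units; beyond the scatter)), so this wholesale change of substituent moves the number no further than the exchange of one para substituent on the retained phenyl ring does. No measurement at hand accounts for any of these numbers.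

Since the carbonyl and the furan enter together, the compounds shown do not separate their contributions; a furan-2-yl set directly on the ring, or a benzoyl group, would divide the change into its two parts. On these data alone, how far this position accepts groups of another kind also stays open, for instance an amine such as morpholin-4-yl or a longer alkyl chain.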